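Chloro-to-methoxy exchange on the aryl ring of compound 3

The source may hold more compounds than are shown below. What is called first, only, known or untested is meant among the compounds shown, and "the series" means these compounds.

Within the data shown here, the three measured members share one core and differ in the aryl groups at either end. Compound 1 `O=C(/C=C\Nc1ccc(O)cc1)c1cn(-c2ccccc2)nc1-c1ccc(F)cc1` gives 4700 nM in a functional assay on U-87MG ATCC cells (Homo sapiens) for antiproliferative activity, read by MTT assay, with a stated time of 48 h; on this read-out higher numbers stand for weaker inhibition and lower numbers for stronger inhibition. Compound 2 `O=C(/C=C\Nc1ccc(Cl)cc1)c1cn(-c2ccccc2)nc1-c1ccc(Cl)cc1` gives 13100 nM in the same read-out. Compound 3 `COc1cc(N/C=C\C(=O)c2cn(-c3ccccc3)nc2-c2ccc(Cl)cc2)cc(OC)c1OC` gives 17800 nM, the highest of the three numbers; against compound 2 the gap stays within the scatter of repeats, while against compound 1 it lies beyond it. Among the measured compounds shown here, no step between two measured compounds that differ in a single place is available, so none of these gaps can be assigned to one change.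

Compound 4 `COc1ccc(-c2nn(-c3ccccc3)cc2C(=O)/C=C\Nc2cc(OC)c(OC)c(OC)c2)cc1` is the next member to be measured. Relative to compound 3 the change is methoxy in place of chloro on an aromatic carbon, para to a large group; cut one bond further out, it reads 4-chlorophenyl to 4-methoxyphenyl. For the measured compounds named here, nothing among the measured compounds isolates this exchange, since compound 1 carries fluoro at that position together with a different aniline. The expectation for the step from compound 3 to compound 4 in this assay is therefore a 1.2-fold lower number from compound 3 to compound 4 (0.07 log units; within the scatter), with no movement beyond the scatter. For compound 4 the estimate in this assay is 15000 nM, within 5000 nM to 45000 nM.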

Compound 4, half-maximal inhibitory concentration: > 50000 nM
Compound 4 ended at the assay's limit (the forecaster's own chance of this, stated with the estimate: 10%); middle value at least 3.3-fold (0.52 log units) away from the limit.
By their numbers in this assay, from the lowest: compound 1; then compounds 2 and 3 (each within the scatter of the next). At a limit, above all of these: compound 4.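

Among these compounds, compound 3 and compound 4 form the first pair that differs in one place, so the exchange of chloro for methoxy, para to a large group, can now be read on its own: in this assay it gives an at least 2.8-fold higher number from compound 3 to compound 4 (0.44 log units; beyond the scatter). Compound 4 gives > 50000 nM, which is a limit of the assay and not a number, so the step has a floor but no measured size. The position is therefore not indifferent to the group it carries, as the move from 4-chlorophenyl to 4-methoxyphenyl alone shifts the read-out beyond the scatter towards weaker inhibition, with the reading resting on a single limit value: the limit of > 50000 nM in this assay, at which 1 of the 4 values shown sits.

As far as these compounds go, how other groups at this position would read with the aniline end of compound 3 remains open, whether fluoro, which appears only in compound 1 together with a different aniline, or an amine, a hydroxyl or a longer chain such as ethoxy. Also open, from the compounds shown here alone, is whether the same exchange of chloro for methoxy would shift the number in the same direction with the aniline end of compound 1 or compound 2.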